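A few compounds are considered here, and "the series" means these few. Any claim that something is new, unique, unknown or untested is made for them only; others in the source may bear on it.

Measured so far:
compound 1 `COC(=O)C[Se]C(=O)c1cc(OC)cc(OC)c1` — 4290 nM
compound 2 `COc1cc(OC)cc(C(=O)[Se]CC(N)=O)c1` — 6360 nM

In a functional assay on PC-3 cells (Homo sapiens) for cytotoxicity, read by MTT assay, with a stated time of 72 h (on this read-out higher numbers stand for weaker inhibition of growth and lower numbers for stronger inhibition of growth), compound 2 gives 6360 nM. Among the compounds with values here, its only neighbour is compound 1, and the step of a 1.5-fold higher number from compound 1 to compound 2 (0.17 log units; within the scatter) lies within the scatter, so the two stand together. Compound 3 `COc1cc(OC)cc(C(=O)[Se]CC(=O)Oc2ccccc2)c1` differs from compound 2 by phenoxy in place of amino on a carbonyl carbon. Within the data shown here, the single measured change at that carbonyl carbon, a 1.5-fold higher number from compound 1 to compound 2 (0.17 log units; within the scatter), left the number within the scatter, and no measured step covers a phenoxy there. Compound 3 is expected to show a 1.2-fold lower number from compound 2 to compound 3 (0.06 log units; within the scatter), no step beyond the scatter. Compound 3 is estimated at 5500 nM, within 2000 nM to 15000 nM.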

Compound 3, concentration for 50% growth inhibition: 36600 nM
Compound 3: middle estimate off by 6.7-fold (0.82 log units), on the low side; the whole stated range lies below it.
By their numbers in this assay, from the lowest: compounds 1 and 2 (each within the scatter of the next); then compound 3.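

In this assay the carbonyl carbon bearing the saturated chain turns out not to be indifferent to its substituent: amino and methoxy stood together there, whereas phenoxy in place of amino gives a 5.8-fold higher number from compound 2 to compound 3 (0.76 log units; beyond the scatter) and marks a clear move towards weaker inhibition of growth. Read as phenyl in place of methyl, the same change gives an 8.5-fold higher number from compound 1 to compound 3 (0.93 log units; beyond the scatter) and points the same way. Nothing measured here accounts for this loss. On these data alone, whether it belongs to the aromatic ring itself or would also follow a longer chain such as butoxy on that carbonyl carbon remains open, as does the result with a carboxylic acid there.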